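Metabolic stability in the series: methylamino replacing isopropyl

A few compounds are considered here, and "the series" means these few. Any claim that something is new, unique, unknown or untested is made for them only; others in the source may bear on it.

Measured so far:
compound 1 `COc1cc(-c2cnn3cc(OC)c(C(C)C)nc23)ccn1`, 14%
compound 2 `Cn1cc(-c2nc3c(-c4ccnc(OC5CC5)c4)cnn3cc2OCCCC(C)(C)O)cn1`, 64%
compound 3 `COc1cc(-c2cnn3cc(OC)c(C)nc23)ccn1`, 13%

In an ADME assay on microsomes from liver (Rattus norvegicus) for metabolic stability, with a stated time of 60 min, tested at 1 uM (a higher number here means that more of the compound is left, a lower number that less of the compound is left), compound 1 gives 14%, the second highest of the three numbers. Its nearest neighbour is compound 3 with 13%; the step of a number 1 percentage points lower from compound 1 to compound 3 (within the scatter) lies within the scatter. Among the compounds with values here, compound 2, which carries a different set of substituents throughout, stands furthest away with 64%, and no single-point step connects it to compound 1.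

Compound 4 `CNc1nc2c(-c3ccnc(OC)c3)cnn2cc1OC` is not yet measured. Relative to compound 1 the change is methylamino in place of isopropyl on an aromatic carbon. Within the data shown here, only the step from compound 1 to compound 3 bears on this position, and it shows that exchanging the isopropyl for a smaller group left the read-out unchanged within the scatter. For compound 4 a similar outcome is therefore expected in this assay, with the step of a number 6 percentage points higher from compound 1 to compound 4 (within the scatter) estimated to stay close to the scatter. Compound 4 is estimated at 20%, in the range 8% to 40%.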

Compound 4, percent of the compound remaining: 74%
Estimate against measurement, compound 4: 54 percentage points below; the whole stated range lies below it.
By their numbers in this assay, from the lowest: compounds 3 and 1 (each within the scatter of the next); then compounds 2 and 4 (each within the scatter of the next).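

In this assay the aromatic carbon next to the ring nitrogen is not indifferent to what it carries: methylamino in place of isopropyl gives a large change (a number 60 percentage points higher from compound 1 to compound 4 (beyond the scatter)), and methylamino in place of methyl gives another (a number 61 percentage points higher from compound 3 to compound 4 (beyond the scatter)). The exchange between the two alkyl groups (a number 1 percentage points lower from compound 1 to compound 3 (within the scatter)) had left the read-out flat, so the alkyl pair gave no sign of what a nitrogen-linked group would do here. No measurement in hand accounts for the shift to methylamino.

On these data alone, whether the shift follows the nitrogen link itself or needs its methyl stays open, and a primary amine, dimethylamino or a longer alkylamino chain at this position would separate the two. Also open, as far as these compounds go, is whether the same exchange holds with other groups on the shared core.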